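A few compounds are considered here, and "the series" means these few. Any claim that something is new, unique, unknown or untested is made for them only; others in the source may bear on it.

Compound 1 `CCC(C)(C)Cc1c[nH]c(CCc2ccc(-c3cccc(C#N)n3)cc2)n1` gives 115 nM in a functional assay on HEK293 cells for agonist activity at Bombesin receptor subtype-3 (Mus musculus), read by luminescence and calcium flux, with a stated time of 10 min; on this read-out higher numbers stand for an effect only at larger amounts of compound and lower numbers for an effect already at smaller amounts. Compound 2 `CCC(C)(C)Cc1c[nH]c(CCc2ccc(-c3ccc(F)cn3)cc2)n1` gives 105 nM in this assay. Compound 3 `CCC(C)(C)Cc1c[nH]c(CCc2ccc(-c3cccnc3)cc2)n1` gives 97 nM in this assay.

Compound 3 holds the lowest of the three numbers, but the steps that reach it, a 1.2-fold lower number from compound 1 to compound 3 (0.07 log units; within the scatter) and a 1.1-fold lower number from compound 2 to compound 3 (0.03 log units; within the scatter), both lie within the scatter, as does a 1.1-fold lower number from compound 1 to compound 2 (0.04 log units; within the scatter); on these numbers the three compounds stand together. Compound 4 `CCC(C)(C)Cc1c[nH]c(CCc2ccc(-c3cccnc3C(=O)O)cc2)n1` carries carboxy in place of hydrogen on an aromatic carbon, placed next to the ring nitrogen and ortho to a large group. For the measured compounds named here, none of the measured steps adds a group of this kind; each exchanges one pyridinyl group for another and stays within the scatter. They bear on the step from compound 3 to compound 4 only by showing that this part of the molecule has so far accepted small changes without a shift beyond the scatter. The carboxy group is new ground, so a moderate rise beyond the scatter, with a wide range, is what is expected, and the step of a 2.6-fold higher number from compound 3 to compound 4 (0.41 log units; beyond the scatter) is estimated on that basis. Compound 4 is expected to give 250 nM in this assay, within a range from 70 nM to 1500 nM.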

Compound 4, half-maximal effective concentration: 97 nM
The estimate for compound 4 lay 2.6-fold (0.41 log units) above the measured number; the range from low to high includes it.
By their numbers in this assay, from the lowest: compounds 3, 4, 2 and 1 (each within the scatter of the next).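

In this assay the step that adds carboxy in place of hydrogen on an aromatic carbon, next to the ring nitrogen and ortho to a large group, shows no change at the digits printed from compound 3 to compound 4 (within the scatter) and thus extends what this part of the molecule accepts from exchanges of one pyridinyl group for another to an added group. The comparisons with the other two compounds agree, with a 1.1-fold lower number from compound 2 to compound 4 (0.03 log units; within the scatter) and a 1.2-fold lower number from compound 1 to compound 4 (0.07 log units; within the scatter), so 2-carboxypyridin-3-yl stands together with the three earlier aryl groups. Nothing available explains this result.

As far as these compounds go, it remains open whether a methyl ester, a primary amide or an aminomethyl group would be accepted in the same place as the carboxy group. From the compounds shown here alone, it also remains open whether a carboxy group would be accepted on another carbon of the pyridine ring.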